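Halogenated analogues of compound 1: cytotoxicity notes

This account rests on a few compounds, and the source may have more. Where it says the series, first, only, none or still open, it means among the compounds named here.

compound 1 `OCc1cn(Cc2ccccc2)c2ccccc12`: 14500 nM
compound 2 `OCc1cn(Cc2cccc(F)c2)c2ccccc12`: > 31600 nM (a limit, not a number)
compound 3 `OCc1cn(Cc2ccc(Cl)cc2)c2ccccc12`: > 31600 nM (a limit, not a number)

In an ADME assay on T29 cells (Homo sapiens) for cytotoxicity, read by sulforhodamine B assay, with a stated time of 3 days (a lower number here means a stronger inhibitor, a higher number a weaker inhibitor), compound 1 gives 14500 nM. Compound 2 reaches only a limit of the assay, > 31600 nM. Compound 3 likewise reaches only a limit, > 31600 nM. The steps of an at least 2.1-fold higher number from compound 1 to compound 2 (0.33 log units; beyond the scatter) and an at least 2.1-fold higher number from compound 1 to compound 3 (0.33 log units; beyond the scatter) are therefore lower bounds because the limit of > 31600 nM in this assay, at which 2 of the 3 values shown sit, caps both. The change fluoro in place of hydrogen on an aromatic carbon and the change chloro in place of hydrogen on an aromatic carbon both weaken the series in this assay by at least a modest amount.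

Compound 4 `OCc1cn(Cc2ccc(Cl)cc2)c2ccc(F)cc12` is not yet measured. It differs from compound 3 by fluoro in place of hydrogen on an aromatic carbon. This is the same kind of change as fluoro in place of hydrogen on an aromatic carbon, but not the same: there the place was meta to a large group, here it is part of a fused or bridged system of two rings, meta to a fused ring and para to a fused ring. The two cores differ by chloro in place of hydrogen on an aromatic carbon.

Compound 3 sits at a limit, and the earlier change of this kind weakened by at least a modest step, so compound 4 is expected to remain at or beyond the limit. The expected step is a step that the limit leaves unreadable from compound 3 to compound 4. Compound 4 is estimated at 45000 nM, within 15000 nM to 120000 nM.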

Compound 4, half-maximal inhibitory concentration: 8120 nM
Estimate against measurement, compound 4: 5.5-fold (0.74 log units) above, outside the stated range (below it).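

In this assay, fluoro in place of hydrogen on an aromatic carbon gives an at least 3.8-fold lower number from compound 3 to compound 4 (0.59 log units; beyond the scatter). The change therefore does not carry over from one core to the other with the same direction in this series: the same change on two cores in this assay, an at least 2.1-fold higher number (0.33 log units; beyond the scatter) from compound 1 to compound 2 and an at least 3.8-fold lower number (0.59 log units; beyond the scatter) from compound 3 to compound 4, at least 8.4-fold (0.92 log units) apart, beyond the scatter of two such steps

The two steps differ both in the core, which carries chloro in one case only, and in the place of the fluoro; the compounds shown do not separate these two, and neither step has a readable full size: the limit of > 31600 nM in this assay, at which 2 of the 4 values shown sit.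

Still open, as far as these compounds go, is whether fluoro at this place on the fused system lowers the number without the chloro on the other ring, as the core of compound 1 would show. Also open, from the compounds shown here alone, is whether another group at the same place, such as a methoxy group, a nitrile or an amine, moves the number in the same direction as the fluoro of compound 4.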